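Swapping 4-Hydroxyphenyl for 3-Chlorophenyl

A few compounds are considered here, and "the series" means these few. Any claim that something is new, unique, unknown or untested is made for them only; others in the source may bear on it.

Compound 1 `CC1=CC[C@H](C(C)(C)NC(=S)NN)CC1` is the simplest member here, and in a functional assay on MCF7 cells (Homo sapiens) for inhibition, read by sulforhodamine B assay, with a stated time of 48 h (a lower number here means a stronger inhibitor of growth, a higher number a weaker inhibitor of growth), compound 1 gives 46700 nM. Compound 2 `CC1=CC[C@H](C(C)(C)NC(=S)N/N=C/c2ccc(O)cc2)CC1` carries a 4-hydroxyphenyl on a carbon with a double bond to nitrogen. In this assay compound 2 reaches only a limit, > 100000 nM, so no number for it is known; this is the limit of > 100000 nM in this assay, at which 1 of the 2 values shown sits. Compound 3 `CC1=CC[C@H](C(C)(C)NC(=S)N/N=C/c2cccc(Cl)c2)CC1` differs from compound 2 by 3-chlorophenyl in place of 4-hydroxyphenyl on a carbon with a double bond to nitrogen. Among the measured compounds shown here, no measured step covers such a change, so the expectation rests on compound 2 alone. Compound 3 is expected to stay a weak inhibitor, with an estimated value of 60000 nM and a range from 15000 nM to 200000 nM. The expected step of an at least 1.6-fold lower number from compound 2 to compound 3 (0.22 log units; that floor lies within the scatter) would be a gain, though not one clearly beyond the scatter.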

Compound 3, concentration for total growth inhibition: 61000 nM
The estimate for compound 3 lay 1.0-fold (0.01 log units) below the measured number, and the stated range covers the measured number.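

On a carbon with a double bond to nitrogen, 3-chlorophenyl in place of 4-hydroxyphenyl gives an at least 1.6-fold lower number from compound 2 to compound 3 (0.21 log units; that floor lies within the scatter), so this assay shows no gain clearly beyond the scatter. The change does give this position its first measured number with an aromatic ring attached, in compound 3. Compound 2 remains a limit, so the true size of the step cannot be read: the limit of > 100000 nM in this assay, at which 1 of the 3 values shown sits.

Going by these compounds, whether an amine or a carboxylic acid on this ring would bring a clear gain stays open. So does the effect of a 4-chlorophenyl here.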